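From methoxymethyl to 4-fluorophenyl on a carbonyl carbon

This account rests on a few compounds, and the source may have more. Where it says the series, first, only, none or still open, it means among the compounds named here.

Measured in a physicochemical assay for solubility, at pH 6.8; on this read-out lower numbers stand for lower solubility and higher numbers for higher solubility:
- Compound 1 `Nc1ccc(CNC(=O)Nc2ccc(CN3C(=O)c4ccccc4C3=O)cc2)cn1`: < 5000 nM, a limit of the assay and not a number
- Compound 2 `C[C@H](NC(=O)C1CCOCC1)c1ccc(NC(=O)[C@H]2C[C@@H]2c2cccnc2)cc1`: 90000 nM
- Compound 3 `COCC(=O)N[C@@H](C)c1ccc(NC(=O)[C@H]2C[C@@H]2c2cccnc2)cc1`: 520000 nM

Of the two actual numbers in this assay, the higher belongs to compound 3, at 520000 nM. Its nearest neighbour is compound 2, at 90000 nM. Among the measured compounds shown here, compound 1 is known only as a limit, and no measured step connects it to the others.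

The next compound is compound 4 `C[C@H](NC(=O)c1ccc(F)cc1)c1ccc(NC(=O)[C@H]2C[C@@H]2c2cccnc2)cc1`, which carries 4-fluorophenyl in place of methoxymethyl on a carbonyl carbon, the carbon whose other neighbour is an amide-type nitrogen: 4-fluorophenyl in place of methoxymethyl on a carbonyl carbon.

For the measured compounds named here, only one measured step bears on this change. It acts on the same carbonyl carbon, where methoxymethyl takes the place of oxan-4-yl: a 5.8-fold higher number from compound 2 to compound 3 (0.76 log units; beyond the scatter). That step is modest but beyond the scatter, and it shows that compound 3, with the open chain, gives the higher number and compound 2, with the ring, the lower.

Compound 4 also places a ring there, so a lower number is expected, with a step at least comparable in size to the measured one. The estimated change is a 21-fold lower number from compound 3 to compound 4 (1.32 log units; beyond the scatter). For compound 4 the expected value is 25000 nM, with an estimated range from 6000 nM to 100000 nM.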

Compound 4, solubility: 6000 nM
For compound 4 the middle estimate is 4.2-fold (0.62 log units) above the measured one, and the stated range covers the measured number.
By their numbers in this assay, from the lowest: compound 4; then compound 2; then compound 3. At a limit, below all of these: compound 1.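

Among the compounds shown here, the position on the carbonyl carbon proves far more sensitive in this assay than the earlier pair suggested, with an 87-fold lower number from compound 3 to compound 4 (1.94 log units; beyond the scatter) marking a large step where the only earlier step was modest. A ring as such does not settle the number, as a 15-fold lower number from compound 2 to compound 4 (1.18 log units; beyond the scatter) is also large, although oxan-4-yl and 4-fluorophenyl are both rings, the latter a six-membered aromatic ring of carbon only. Compound 4 has the lowest actual number of the three compounds that differ at this position, yet it is still reported as a number, and only compound 1 stands at a limit of the assay: the limit of < 5000 nM in this assay, at which 1 of the 4 values shown sits.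

The compounds shown leave open whether the large step follows the aromatic ring or its fluorine, a question that plain phenyl or a pyridine ring on the same carbonyl carbon would address. They also do not show whether an open chain carrying an amine or a carboxylic acid would match or exceed methoxymethyl in this assay.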